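The source may report more compounds than this note shows. Statements on the series, on what has been measured and on what is new or still open speak of the compounds shown alone.

Measured compounds:
compound 1 `COc1ccc(/C=C/C[C@H]2C[C@H]([C@H](O)c3ccc(OC)c(OC)c3)CO[C@@H]2c2ccc(OC)c(OC)c2)cc1OC` — 23500 nM
compound 2 `Oc1ccc(/C=C/C[C@H]2C[C@@H]([C@@H](O)c3ccccc3)CO[C@@H]2c2ccccc2)cc1` — 7380 nM
compound 3 `COc1cccc(/C=C/C[C@H]2C[C@@H]([C@@H](O)c3ccccc3)CO[C@@H]2c2ccccc2)c1` — 9620 nM

In a functional assay on HL-60 cells (Homo sapiens) for cytotoxicity, read by WST assay, with a stated time of 48 h (on this read-out higher numbers stand for weaker inhibition and lower numbers for stronger inhibition), compound 1 gives 23500 nM, the highest of the three numbers, so the weakest inhibition: compound 3 sits at a lower number (beyond the scatter) and compound 2 at a lower number still (beyond the scatter). Among the compounds with values here, compounds 2 and 3 lie within the scatter of each other; the one step recorded, a 1.3-fold higher number from compound 2 to compound 3 (0.12 log units; within the scatter), is an aryl exchange on the double-bonded chain and says nothing about configuration.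

Compound 4 `COc1ccc(/C=C/C[C@@H]2C[C@@H]([C@@H](O)c3ccc(OC)c(OC)c3)CO[C@H]2c2ccc(OC)c(OC)c2)cc1OC` has not been measured. It differs from compound 1 as follows: the two compounds have the same atoms and bonds and differ only in configuration as drawn: 4 of 5 stereo elements differ; a stereocentre at a saturated ring carbon is drawn S in compound 1 and R in compound 4; a stereocentre at a saturated ring carbon is drawn S in compound 1 and R in compound 4; a stereocentre at a saturated chain carbon is drawn S in compound 1 and R in compound 4; a stereocentre at a saturated ring carbon is drawn S in compound 1 and R in compound 4. Within the data shown here, no measured pair in this set differs only in configuration, so the size of such a step is unknown here; the aryl exchange from compound 2 to compound 3 does not bear on it. The working assumption is therefore a number close to that of compound 1, with a wide range to admit a real shift in either direction.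

For compound 4 the expected value in this assay is 20000 nM, between 6000 nM and 60000 nM, which is an estimated step of a 1.2-fold lower number from compound 1 to compound 4 (0.07 log units; within the scatter) from compound 1.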

Compound 4, half-maximal inhibitory concentration: 26000 nM
Beside the measured number, compound 4's estimate is 1.3-fold (0.11 log units) below it, within the range that was stated.
By their numbers in this assay, from the lowest: compounds 2 and 3 (each within the scatter of the next); then compounds 1 and 4 (each within the scatter of the next).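

In this assay the configurational change gives a 1.1-fold higher number from compound 1 to compound 4 (0.04 log units; within the scatter), so inverting four of the five stereo elements as drawn leaves the two numbers within the scatter of each other. Within the data shown here, compounds 1 and 4 form the first pair to address configuration, which the aryl exchange among the earlier compounds could not do, and in this pair the read-out does not separate the two drawn forms. The reading rests on a comparison with no other structural difference to account for it: the fact that compounds 1 and 4 differ only in the configuration as drawn.

On these data alone, the pair moves four stereo elements at once, so it remains open whether each one is individually silent, whether opposing contributions cancel, and what the fifth element, shared by both compounds, contributes. As far as these compounds go, it also remains open whether the same insensitivity to configuration holds on the unsubstituted phenyl groups of compound 2 and compound 3, or when an aminophenyl or a carboxyphenyl group stands in place of the 4-hydroxyphenyl on the double-bonded chain.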